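The source may hold more compounds than are shown below. What is called first, only, known or untested is meant among the compounds shown, and "the series" means these compounds.

Working notes on the series.

In a functional assay on HEK293 cells for antagonist activity at thromboxane A2 receptor (Homo sapiens), read by fluorescence and calcium flux (on this read-out lower numbers stand for stronger inhibition and higher numbers for weaker inhibition), compound 1 `Cc1cccc(Oc2ccc(C#N)cc2S(=O)(=O)NC(=O)NC(C)C)c1` gives 1690 nM. Going by the values given here, compound 2 `Cc1cccc(Oc2ccc(C#N)cc2S(=O)(=O)NC(=O)NC(C)(C)C)c1` differs from it in one place, and in this assay compound 2 gives 690 nM, the lowest of the two numbers measured so far; the only step that relates to it is a 2.4-fold lower number from compound 1 to compound 2 (0.39 log units; beyond the scatter). Compound 3 `CCCCCNC(=O)NS(=O)(=O)c1cc(C#N)ccc1Oc1cccc(C)c1` is not yet measured. It differs from compound 2 by pentyl in place of tert-butyl on an amide-type nitrogen. Among the compounds with values here, no measured step covers the exchange of a branched chain for a straight one on this nitrogen; the one measured step, from compound 1 to compound 2, adds a methyl on the chain carbon bound to the nitrogen, which bears on the size of the group there but not on its shape. Within the data shown here, the step to compound 3 therefore has no direct precedent, and an outcome within the scatter of compound 2 is as plausible as a change in either direction. The estimate for compound 3 is 800 nM, between 250 nM and 2500 nM, which is expected to mean a step of a 1.2-fold higher number from compound 2 to compound 3 (0.06 log units; within the scatter).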

Compound 3, half-maximal inhibitory concentration: 680 nM
Estimate against measurement, compound 3: 1.2-fold (0.07 log units) above; the range from low to high includes it.
By their numbers in this assay, from the lowest: compounds 3 and 2 (each within the scatter of the next); then compound 1.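

In this assay, pentyl in place of tert-butyl on the amide-type nitrogen gives a 1.0-fold lower number from compound 2 to compound 3 (0.01 log units; within the scatter) and so leaves the read-out unchanged within the scatter; a straight chain here serves as well as a branched one, which the earlier pair, holding branched groups only, could not show. The other new comparison, a 2.5-fold lower number from compound 1 to compound 3 (0.40 log units; beyond the scatter), runs the same way as a 2.4-fold lower number from compound 1 to compound 2 (0.39 log units; beyond the scatter), so among these three compounds isopropyl is the group that stands apart, and moving away from it does not depend on keeping the branch. No supporting data on the series bear on this result, and the reading therefore stays descriptive.

Open, on these data alone, is whether a longer chain such as octyl, a cyclohexyl ring or a chain ending in a carboxylic acid would keep the number at this level or move it in either direction. Also open, as far as these compounds go, is whether a shorter straight chain such as propyl matches isopropyl or pentyl, and whether the match between pentyl and tert-butyl holds once the nitrile on the shared core is replaced.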